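Thiophene Isomer Swap in a Pair with Low Numbers

A few compounds are considered here, and "the series" means these few. Any claim that something is new, unique, unknown or untested is made for them only; others in the source may bear on it.

Compound 2, `CCSC(=O)C1=C(C)NC(=O)NC1c1cccs1`, was examined in an assay on membranes from CHO cells for displacement of a labelled ligand from adenosine receptor A1 (Homo sapiens), read by scintillation counting, with a stated time of 60 min, tested at 1 uM; on this read-out lower numbers stand for less inhibition and higher numbers for more inhibition at the one concentration tested (going by the name of the read-out). In this assay, for the measured compounds named here, compound 2 gives 6%, which places it at the bottom of the two numbers recorded so far, although the gap to its only neighbour lies within the usual scatter. That neighbour, compound 1, `CC(=O)C1=C(C)NC(=O)NC1c1ccsc1`, gives 9% in this assay, so the two values can be read only as two similarly small numbers, with no order between them. Compound 3, `CCSC(=O)C1=C(C)NC(=O)NC1c1ccsc1`, is an untested analogue of compound 2 that keeps the (ethylsulfanyl)carbonyl group and the methyl group of the shared core and differs in one place only: thiophen-3-yl in place of thiophen-2-yl on a saturated ring carbon. Going by the values given here, no pair of measured compounds differs in a single place, so the effect of this change has not been observed directly. Both measured numbers sit near the low end of the scale, and the step of a number 2 percentage points higher from compound 2 to compound 3 (within the scatter) is therefore expected to be none beyond the scatter. Compound 3 is estimated to give 8% in this assay, with an expected range from 0% to 20%.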

Compound 3, a percentage reported as inhibition, at one concentration (the size of the read-out at that concentration, not a potency): 11%
Beside the measured number, compound 3's estimate is 3 percentage points below it; measured number inside the range.
By their numbers in this assay, from the lowest: compounds 2, 1 and 3 (each within the scatter of the next).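

In this assay, for the compounds shown here, the thiophene swap on a saturated ring carbon, next to the ring nitrogen, now has a direct reading, which the earlier compounds could not give: thiophen-3-yl in place of thiophen-2-yl gives a number 5 percentage points higher from compound 2 to compound 3 (within the scatter) and so leaves the two attachments of the ring indistinguishable in this read-out. A second single-place comparison also becomes available on the carbonyl carbon, where ethylsulfanyl in place of methyl gives a number 2 percentage points higher from compound 1 to compound 3 (within the scatter) and the two groups likewise cannot be told apart here. Nothing available accounts for either reading.

All three compounds stay close together at the low end of the scale, so neither comparison shows whether this position or the carbonyl carbon can affect the number in this assay at all. As far as these compounds go, it remains open whether a phenyl or a pyridin-3-yl group in place of the thiophene on the saturated ring carbon, or an amine or a longer chain such as butylsulfanyl in place of ethylsulfanyl on the carbonyl carbon, would give a number clearly apart from these.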